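The source may report more compounds than this note shows. Statements on the series, on what has been measured and on what is new or still open speak of the compounds shown alone.

Measured so far in a functional assay on KBVIN cells (Homo sapiens) for antiproliferative activity, read by sulforhodamine B assay, with a stated time of 3 days; a higher number here means that more compound is needed for the effect, a lower number that less compound is needed:
compound 1 `CCCOC1=C(CCC)C(=O)/C(=C(O)/C=C/c2ccccc2)C(=O)C1(CCC)CCC`: 2.4 uM
compound 2 `COC1=C(CC=C(C)C)C(=O)/C(=C(O)/C=C/c2ccccc2)C(=O)C1(CC=C(C)C)CC=C(C)C`: 8.9 uM
compound 3 `COC1=C(CCC(C)C)C(=O)/C(=C(O)/C=C/c2ccccc2)C(=O)C1(CCC(C)C)CCC(C)C`: 20.3 uM

Compound 1 has the lowest number of the three. Compound 2 sits higher, beyond the scatter, and compound 3 sits higher still. Going by the values given here, both compound 2 and compound 3 differ from compound 1 in more than one place, so no pair of measured compounds isolates a single change.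

Compound 4 `CCCC1=C(OC)C(CCC)(CCC)C(=O)/C(=C(O)\C=C\c2ccccc2)C1=O` differs from compound 1 in one place: hydrogen in place of ethyl on a saturated chain carbon bound to an oxygen on an unsaturated carbon. Cut one bond further out, the same difference reads propoxy to methoxy. Among the compounds with values here, with no measured pair showing this change alone, the step of a 1.5-fold higher number from compound 1 to compound 4 (0.16 log units; within the scatter) is expected to be small, toward a slightly higher number if anything, and likely within the scatter. Compound 4 is therefore expected to give about 3.5 uM in this assay, within a range from 1.2 uM to 10 uM.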

Compound 4, concentration for half-maximal effect: 3.4 uM
Estimate against measurement, compound 4: 1.0-fold (0.01 log units) above; the range from low to high includes it.
By their numbers in this assay, from the lowest: compounds 1 and 4 (each within the scatter of the next); then compound 2; then compound 3.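

Going by these compounds alone, this pair is the first to isolate one change, propoxy to methoxy, with the rest of the core of compound 1 kept. In this assay that change gives a 1.4-fold higher number from compound 1 to compound 4 (0.15 log units; within the scatter) and so removes ethyl from this chain without a shift that can be told from the usual scatter of repeat measurements. Nothing available here offers an explanation for this result.

Only propoxy and methoxy are shown at this position. On these data alone, a longer chain such as hexyloxy, or a chain ending in an amine or a carboxylic acid, remains open.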